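A few compounds are considered here, and "the series" means these few. Any claim that something is new, unique, unknown or untested is made for them only; others in the source may bear on it.

Measured so far:
compound 1 `COc1ccc(C2C(C#N)=C(N)N(c3cc(OC)c(OC)c(OC)c3)C3=C2C(=O)CC(C)(C)C3)cc1` — 1%
compound 2 `COc1cc(N2C(N)=C(C#N)C(c3c(OC)ccc4ccccc34)C3=C2CC(C)(C)CC3=O)cc(OC)c1OC` — 5%

Both numbers come from a functional assay on Ehrlich cells (Mus musculus) for cytotoxicity, tested at 25 ug/mL; on this read-out lower numbers stand for a weaker effect and higher numbers for a stronger effect at the one concentration tested. Compound 2 stands highest of the two numbers shown, but the only step measured so far, a number 4 percentage points higher from compound 1 to compound 2 (within the scatter), is within the scatter, so the two compounds are not separated by this assay; both sit near the bottom of the read-out.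

Compound 3 `COc1cc(N2C(N)=C(C#N)C(c3ccccc3O)C3=C2CC(C)(C)CC3=O)cc(OC)c1OC` is the next compound to be measured in this assay. The change from compound 2 is 2-hydroxyphenyl in place of 2-methoxynaphthalen-1-yl on a saturated ring carbon. Among the compounds with values here, the one measured step that bears on it is the exchange of the aryl group on the same saturated ring carbon, a number 4 percentage points higher from compound 1 to compound 2 (within the scatter), which stayed within the scatter. On that basis no step beyond the scatter is expected, and the estimated step is a number 1 percentage points lower from compound 2 to compound 3 (within the scatter). Within the data shown here, there is no measured example of a hydrogen-bond donor entering at this position, so the expectation rests on that single step alone.

Compound 3 is expected to give 4% in this assay, with a range from 0% to 15%.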

Compound 3, a percentage reported as activity, at one concentration (the size of the read-out at that concentration, not a potency): 0%
For compound 3 the middle estimate is 4 percentage points above the measured one; measured number inside the range.
By their numbers in this assay, from the lowest: compounds 3, 1 and 2 (each within the scatter of the next).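

In this assay, the saturated ring carbon now carries three different aryl groups, and neither new step leaves the scatter (a number 5 percentage points lower from compound 2 to compound 3 (within the scatter); a number 1 percentage points lower from compound 1 to compound 3 (within the scatter)). Compound 3 adds two contrasts to the earlier exchange: 2-hydroxyphenyl has one six-membered aromatic ring where 2-methoxynaphthalen-1-yl has two, and it brings 1 hydrogen-bond donor where the groups in compound 1 and compound 2 bring none, yet neither contrast separates the compounds in this read-out. No measurement is available that could explain this result or tie it to any feature of these groups.

From the compounds shown here alone, all three compounds sit near the bottom of the read-out at the one concentration tested, so it remains open whether any group on this carbon can lift the number clear of the scatter, for example a carboxylic acid or a dimethylamino group on the aryl ring. Going by these compounds, the part played by the 3,4,5-trimethoxyphenyl group, shared by all three compounds, also stays open, as a smaller group such as a plain phenyl there has no number.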